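The source may hold more compounds than are shown below. What is called first, only, known or untested is meant among the compounds shown, and "the series" means these compounds.

Measured so far:
compound 1, `CC(C)(N)CC(=O)N[C@@H]1CCc2ccccc2N(Cc2ccc(-c3ccccc3C(=O)NCc3ccccc3)cc2)C1=O`: 0.9 uM
compound 2, `COc1ccc(CNC(=O)c2ccccc2-c2ccc(CN3C(=O)[C@H](NC(=O)CC(C)(C)N)CCc4ccccc43)cc2)cc1`: 2 uM
compound 3, `CC(C)(N)CC(=O)N[C@@H]1CCc2ccccc2N(Cc2ccc(-c3ccccc3C(=O)NCCCCCO)cc2)C1=O`: 0.01 uM

All three were tested in a functional assay (Pituitary gland cell) with Rattus norvegicus as the target; a lower number here means that less compound is needed, a higher number that more compound is needed for the effect. Compound 3 gives the lowest number of the three; the nearer step, a 90-fold lower number from compound 1 to compound 3 (1.95 log units; beyond the scatter), and the further one, a 200-fold lower number from compound 2 to compound 3 (2.30 log units; beyond the scatter), both lie beyond the scatter. Compound 4, `CCCCCNC(=O)c1ccccc1-c1ccc(CN2C(=O)[C@H](NC(=O)CC(C)(C)N)CCc3ccccc32)cc1`, differs from compound 3 by a single change: hydrogen in place of hydroxy on a saturated chain carbon, five bonds along the chain from an amide-type nitrogen. Among the measured compounds shown here, no measured step isolates this hydroxy. The two large steps leading to compound 3 swapped an aromatic group for the whole hydroxy-bearing chain, so they bear on the change only indirectly. What part of those steps goes with the hydroxy and what part with the rest of the chain cannot be told apart from the measured compounds. Without a direct comparison, a step beyond the scatter but well short of those two seems most likely, toward a higher number; the expected step is a 3.0-fold higher number from compound 3 to compound 4 (0.48 log units; beyond the scatter). Compound 4 is therefore estimated at 0.03 uM, within a range from 0.008 uM to 0.15 uM.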

Compound 4, concentration for half-maximal effect: > 1 uM
Compound 4 was reported as a limit; the forecaster's own chance of this, stated with the estimate: 2%; middle value at least 33-fold (1.52 log units) from the limit.
By their numbers in this assay, from the lowest: compound 3; then compound 1; then compound 2.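

Compound 4 stands only as a limit: the limit of > 1 uM in this assay, at which 1 of the 4 values shown sits. Losing this one hydroxy on a saturated chain carbon, five bonds along the chain from an amide-type nitrogen, gives an at least 100-fold higher number from compound 3 to compound 4 (2.00 log units; beyond the scatter), so in this assay the low number of compound 3 depends on the hydroxy and not on the chain alone. Without the hydroxy, the chain shows no readable gain over the phenyl group, with an at least 1.1-fold higher number from compound 1 to compound 4 (0.04 log units; that floor lies within the scatter).

As far as these compounds go, the step between compound 2 and compound 4 cannot be read, and the true number for compound 4 remains unknown. From the compounds shown here alone, whether an amine, a carboxylic acid or a longer chain bearing the hydroxy could serve here also remains open.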